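A few compounds are considered here, and "the series" means these few. Any claim that something is new, unique, unknown or untested is made for them only; others in the source may bear on it.

Series notes, following the step from compound 1 to compound 4. Compound 1 `Cc1ccc(CNC(=O)c2ccc(N3C(=O)C4CC=CCC4C3=O)cc2)cc1C` has been run in an assay on isolated protein for inhibition of metabotropic glutamate receptor 5 (Homo sapiens), tested at 10 uM (a lower number here means less inhibition, a higher number more inhibition at the concentration tested (going by the name of the read-out)), where it returns only the assay limit of < 35% rather than a number. Compound 3 `Cc1ccc(NCC(=O)Nc2ccc(N3C(=O)C4CC=CCC4C3=O)cc2)cc1C` likewise sits at the limit of < 35% in this assay. Compound 2 `Cc1ccc2c(c1)C(=O)N(c1ccc(C(=O)OCC(=O)c3ccc(C)c(C)c3)cc1)C2=O` gives 28% in this assay, a number. Compound 1 therefore stands at the limit, supported by the limit of < 35% in this assay, at which 2 of the 3 values shown sit. Compound 4 `Cc1ccc(NC(=O)c2ccc(N3C(=O)C4CC=CCC4C3=O)cc2)cc1C` is not yet measured; it differs from compound 1 by 3,4-dimethylphenyl in place of 3,4-dimethylbenzyl on an amide-type nitrogen. For the measured compounds named here, no measured step for this change exists among the compounds in hand. The expected step that the limit leaves unreadable from compound 1 to compound 4 in this assay is none beyond the scatter. Compound 4 is estimated to give about 20%, in the range from 5% to 35%, most likely again reported only as a limit.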

Compound 4, a percentage reported as inhibition, at one concentration (the size of the read-out at that concentration, not a potency): < 35%
Compound 4: a limit, no number (the forecaster's own chance of this, stated with the estimate: 70%); the middle value does not contradict the limit.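

In this assay, for the compounds shown here, compound 1 and compound 4 both return only a limit, so no step between them can be read. From the compounds shown here alone, whether 3,4-dimethylphenyl and 3,4-dimethylbenzyl on the amide-type nitrogen differ in inhibition remains open.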